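The source may hold more compounds than are shown below. What is called first, only, known or untested is meant among the compounds shown, and "the series" means these compounds.

Compound 1: `COc1ccccc1C(=O)NCc1ccc(CNS(=O)(=O)c2ccccc2F)cc1`, 1 nM
Compound 2: `Cc1ccccc1C(=O)NCc1ccc(CNS(=O)(=O)c2ccccc2Cl)cc1`, 1000 nM

In an assay on MDA-MB-231 cells for displacement of a labelled ligand from C-X-C chemokine receptor type 4 (Homo sapiens), read by fluorescence and microscopy, with stated times of 10 min and 30 min (a lower number here means that less compound is needed, a higher number that more compound is needed for the effect), compound 2 stands at the highest number of the two; compound 1 sits far lower, well beyond the scatter, though the two compounds differ in two places.

Compound 3, `Cc1ccccc1C(=O)NCc1ccc(CNS(=O)(=O)c2ccccc2F)cc1`, is not yet measured. It differs from compound 2 by fluoro in place of chloro on an aromatic carbon, on a six-membered aromatic ring of carbon only, ortho to a large group. Among the compounds with values here, no single-change step is known here. Compound 3 is expected to carry a step of a 33-fold lower number from compound 2 to compound 3 (1.52 log units; beyond the scatter) in this assay, toward a lower number, because compound 1, which holds the same fluoro, gives 1 nM. Compound 3 is expected at about 30 nM, within 2 nM to 500 nM.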

Compound 3, effective concentration (reported as EC, without a stated level of effect): 1000 nM
Compound 3: the middle estimate sits 33-fold (1.52 log units) below what was measured; the whole stated range lies below it.
By their numbers in this assay, from the lowest: compound 1; then compounds 2 and 3 (each within the scatter of the next).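

In this assay, fluoro in place of chloro gives no change at the digits printed from compound 2 to compound 3 (within the scatter), so with methyl on the other side of the molecule, this change of halogen does not move the number. Within the data shown here, the single change of methyl in place of methoxy instead gives a 1000-fold higher number from compound 1 to compound 3 (3.00 log units; beyond the scatter), which places the large gap in this pair at that group and not at the halogen. Nothing shown accounts for either result. On these data alone, it remains open whether chloro and fluoro also read alike with methoxy present, and how an ethoxy or hydroxyl group would read in place of methoxy.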